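Swapping a Sulfonamide Ring for a Chloropyridine

The compounds below may be only part of what the source reports. "The series", "measured", "known", "first", "only" and "open" are said of these compounds alone.

Compound 1 `O=C(O)Cc1sc(C(c2ccc(F)cc2)c2ccc(F)cc2)nc1-c1cc(F)cc(F)c1`: in an in vitro functional assay on HEK285-7 cells for antagonist activity at prostaglandin D2 receptor 2 (Homo sapiens), read by BRET and beta-arrestin recruitment (on this read-out lower numbers stand for stronger inhibition and higher numbers for weaker inhibition), compound 1 gives 340 nM.
Compound 2 `NS(=O)(=O)c1ccc(-c2nc(C(c3ccc(F)cc3)c3ccc(F)cc3)sc2CC(=O)O)cc1`: in this assay compound 2 gives > 100000 nM, which is a limit of the assay and not a number.

Compound 2 thus sits at the weak end of what this assay can report, namely (the limit of > 100000 nM in this assay, at which 1 of the 2 values shown sits), while compound 1 sits far stronger. For the measured compounds named here, the only measured step is an at least 290-fold higher number from compound 1 to compound 2 (2.46 log units; beyond the scatter), a large loss of inhibition that came with the arrival of the sulfonamide-bearing ring.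

Compound 3 `O=C(O)Cc1sc(C(c2ccc(F)cc2)c2ccc(F)cc2)nc1-c1ccnc(Cl)c1` differs from compound 2 by 2-chloropyridin-4-yl in place of 4-sulfamoylphenyl on an aromatic carbon. The group that leaves is exactly the one whose arrival brought an at least 290-fold higher number from compound 1 to compound 2 (2.46 log units; beyond the scatter); the group that enters is smaller by the counted heavy atoms and carries no hydrogen-bond donor. Compound 3 is therefore expected to recover much of the inhibition lost, though not necessarily all of it, since the entering ring is not the ring of compound 1. The expected step is an at least 66-fold lower number from compound 2 to compound 3 (1.82 log units; beyond the scatter). The estimate for compound 3 is 1500 nM, with a range from 200 nM to 15000 nM.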

Compound 3, half-maximal inhibitory concentration: 39 nM
Beside the measured number, compound 3's estimate is 38-fold (1.59 log units) above it, and the stated range ends above it.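

The new result shows that this position, the aromatic carbon next to the ring nitrogen, does not need the 3,5-difluorophenyl ring of compound 1: a ring that holds a nitrogen and carries a chlorine does better in this assay, giving an 8.7-fold lower number from compound 1 to compound 3 (0.94 log units; beyond the scatter), a modest but real gain. Against the sulfonamide-bearing ring the same group gives an at least 2500-fold lower number from compound 2 to compound 3 (3.40 log units; beyond the scatter), so the position itself stays open to strong inhibition, and the collapse seen earlier goes with the 4-sulfamoylphenyl group in particular and not with every change made here. The value of compound 2 is a limit of the assay and not a number, so the true size of this step remains unknown: the limit of > 100000 nM in this assay, at which 1 of the 3 values shown sits.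

Which part of the 2-chloropyridin-4-yl group goes with the gain, the ring nitrogen or the chlorine, stays open, and a comparison with a pyridin-4-yl or a 4-chlorophenyl group at this position would separate the two. Also open, on these data alone, is whether the loss in compound 2 follows the sulfonamide itself, a question that a 4-methylsulfonylphenyl or a 4-carboxyphenyl group could test.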